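The source may hold more compounds than are shown below. What is called first, only, known or untested is meant among the compounds shown, and "the series" means these compounds.

Of the compounds shown here, three built on one shared core have been tested in a functional assay on SW480 cells (Homo sapiens) for antiproliferative activity, read by MTT assay, with a stated time of 48 h; on this read-out lower numbers stand for stronger inhibition and higher numbers for weaker inhibition. Compound 1 `O=c1cc(-n2cc(CNc3ccccc3)nn2)c2cc(Br)ccc2o1` gives 18400 nM, compound 2 `O=c1cc(-n2cc(CSc3ccccc3)nn2)c2cc(Br)ccc2o1` gives 15400 nM, and compound 3 `O=c1cc(-n2cc(COc3ccccc3Br)nn2)c2cc(Br)ccc2o1` gives 20100 nM. Compound 2 sits at the low end of these three numbers, yet the gaps to it are small: a 1.2-fold lower number from compound 1 to compound 2 (0.08 log units; within the scatter) and a 1.3-fold higher number from compound 2 to compound 3 (0.12 log units; within the scatter). Compound 4 `O=c1cc(-n2cc(COc3ccc(F)cc3)nn2)c2cc(Br)ccc2o1` is not yet measured; it differs from compound 2 by 4-fluorophenoxy in place of phenylsulfanyl on a saturated chain carbon bound to an aromatic carbon. The closest guide is the step of a 1.3-fold higher number from compound 2 to compound 3 (0.12 log units; within the scatter), where a related phenoxy group replaced the same phenylsulfanyl group, and a 1.1-fold higher number from compound 1 to compound 3 (0.04 log units; within the scatter) points the same way, so no step beyond the scatter is expected here. Compound 4 is therefore estimated at 17000 nM, within 9000 nM to 34000 nM, meaning an expected change of a 1.1-fold higher number from compound 2 to compound 4 (0.04 log units; within the scatter).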

Compound 4, half-maximal inhibitory concentration: 1770 nM
Compound 4: the middle estimate sits 9.6-fold (0.98 log units) above what was measured; the measured number lies below the stated range.
By their numbers in this assay, from the lowest: compound 4; then compounds 2, 1 and 3 (each within the scatter of the next).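

In this assay, for the compounds shown here, a change on this saturated chain carbon bound to an aromatic carbon can clearly shift the number, which the earlier compounds did not show: (an 8.7-fold lower number from compound 2 to compound 4 (0.94 log units; beyond the scatter)), (an 11-fold lower number from compound 3 to compound 4 (1.06 log units; beyond the scatter)) and (a 10-fold lower number from compound 1 to compound 4 (1.02 log units; beyond the scatter)). An oxygen link alone does not explain this result, as 2-bromophenoxy also carries one, but compound 3 and compound 4 differ in both the halogen and its ring position. No evidence here gives a cause for the shift.

The compounds shown leave open whether the fluorine, its ring position or both matter, which plain phenoxy and 2-fluorophenoxy could separate. They also leave open whether the oxygen link is needed, which 4-fluoroanilino could test.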